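The source may report more compounds than this note shows. Statements on the series, on what has been measured and on what is new or still open speak of the compounds shown alone.

For the measured compounds named here, compound 2, `COc1cc(C2CC(c3cc4ccccc4o3)=NN2C(=O)Nc2ccccc2O)ccc1O`, gives 22000000 nM in a functional assay on microsomes from liver (Rattus norvegicus, strain Wistar) for inhibition, with a stated time of 15 min (on this read-out higher numbers stand for weaker inhibition and lower numbers for stronger inhibition), the lowest of the three numbers measured so far. Compound 1, `COc1cc(C2CC(c3cc4ccccc4o3)=NN2C(=O)Nc2ccccc2)ccc1O`, gives 116000000 nM in this assay, and compound 3, `COc1cc(C2CC(c3cc4ccccc4o3)=NN2C(=O)Nc2ccc(Cl)cc2)ccc1O`, gives 121000000 nM. Between compound 1 and compound 2 the step was a 5.3-fold lower number from compound 1 to compound 2 (0.72 log units; beyond the scatter), whereas between compound 1 and compound 3 the step was a 1.0-fold higher number from compound 1 to compound 3 (0.02 log units; within the scatter). The direct step from compound 2 to compound 3 was a 5.5-fold higher number from compound 2 to compound 3 (0.74 log units; beyond the scatter).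

Compound 4, `COc1cc(C2CC(c3cc4ccccc4o3)=NN2C(=O)Nc2ccc([N+](=O)[O-])cc2)ccc1O`, is not yet measured. It differs from compound 2 in one place: 4-nitrophenyl in place of 2-hydroxyphenyl on an amide-type nitrogen. Going by the values given here, two measured steps bear on this change. The step of a 5.3-fold lower number from compound 1 to compound 2 (0.72 log units; beyond the scatter) shows that the hydroxy on the aromatic carbon accounts for the lower number of compound 2; the step of a 5.5-fold higher number from compound 2 to compound 3 (0.74 log units; beyond the scatter) shows that exchanging 2-hydroxyphenyl for a 4-substituted phenyl returns the number to the range of compound 1. The step of a 1.0-fold higher number from compound 1 to compound 3 (0.02 log units; within the scatter) shows that a chloro in the 4-position made no difference beyond the scatter, so a 4-nitrophenyl in place of 2-hydroxyphenyl is expected to behave like compound 3. Compound 4 is therefore expected to give 110000000 nM in this assay, in the range 35000000 nM to 350000000 nM, an expected step of a 5.0-fold higher number from compound 2 to compound 4 (0.70 log units; beyond the scatter).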

Compound 4, half-maximal inhibitory concentration: 113000000 nM
Beside the measured number, compound 4's estimate is 1.0-fold (0.01 log units) below it; the range from low to high includes it.
By their numbers in this assay, from the lowest: compound 2; then compounds 4, 1 and 3 (each within the scatter of the next).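

In this assay, 4-nitrophenyl in place of 2-hydroxyphenyl on the amide-type nitrogen gave a 5.1-fold higher number from compound 2 to compound 4 (0.71 log units; beyond the scatter), so a second 4-substituted phenyl, carrying a different group from the chloro seen earlier, also lacks the lower number of compound 2. Nitro in place of chloro gave a 1.1-fold lower number from compound 3 to compound 4 (0.03 log units; within the scatter), and nitro in place of hydrogen gave a 1.0-fold lower number from compound 1 to compound 4 (0.01 log units; within the scatter), so the phenyl, 4-chlorophenyl and 4-nitrophenyl groups cannot be told apart on this read-out, and 2-hydroxyphenyl remains the only group shown at this position that sets its compound apart from the others. Nothing measured here gives a reason for that difference. Going by these compounds, what stays open is whether an amine, a carboxylic acid or a methoxy in place of the hydroxy of 2-hydroxyphenyl would keep the lower number of compound 2 or return it to the level of the other three compounds. It is also open whether the hydroxy would have the same effect at another place on the phenyl ring, since every hydroxy-bearing phenyl on this nitrogen shown here is the single 2-hydroxyphenyl group.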